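This account rests on a few compounds, and the source may have more. Where it says the series, first, only, none or still open, it means among the compounds named here.

Among the compounds with values here, compound 1 `O=C(NCc1ccc(S(=O)(=O)c2ccccc2)cc1)c1cc2ccncc2s1` is the one compound in this set with a number in an ADME assay on microsomes from liver (Mus musculus) for metabolic stability, read by LC-MS, with a stated time of 30 min, tested at 1 uM; on this read-out lower numbers stand for a less stable compound and higher numbers for a more stable compound: in that read-out compound 1 gives 21%. Compound 2 `O=C(NCc1ccc(S(=O)(=O)N2CCCCC2)cc1)c1cc2cccnc2s1` gives no number in this assay; its entry there reads "below limit of detection" (no number reported). Compound 3 `O=C(NCc1ccc(S(=O)(=O)c2ccccc2)cc1)c1cc2cnccc2[nH]1` has not yet been measured. It differs from compound 1 by a group of 9 heavy atoms (7 carbon, 2 nitrogen; one five-membered aromatic ring with 1 hetero atom, one six-membered aromatic ring with 1 hetero atom) in place of a group of 9 heavy atoms (7 carbon, 1 nitrogen, 1 sulfur; one five-membered aromatic ring with 1 hetero atom, one six-membered aromatic ring with 1 hetero atom), on a carbonyl carbon. No measured step of this kind exists among these compounds, so the direction is open. The step of a number 4 percentage points higher from compound 1 to compound 3 (within the scatter) is expected to lie within the usual scatter. Compound 3 is therefore estimated at 25% in this assay, with a range from 8% to 50%.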

Compound 3, percent of the compound remaining: 54%
For compound 3 the middle estimate is 29 percentage points below the measured one; the measured number lies above the stated range.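

In this assay, within the data shown here, the change at this place gives a number 33 percentage points higher from compound 1 to compound 3 (beyond the scatter), the first measured step in this set. It shows that the read-out responds strongly to the group on the carbonyl carbon, even though the group that enters has the same kinds of aromatic ring as the one that leaves. Nothing available explains the rise. As far as these compounds go, whether the step follows the loss of sulfur, the added nitrogen or the hydrogen-bond donor remains open. So does how a group with an oxygen in its five-membered aromatic ring would behave at this place.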